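Methyl added to the aryl ring of the hydroxymethyl analogue

A few compounds are considered here, and "the series" means these few. Any claim that something is new, unique, unknown or untested is made for them only; others in the source may bear on it.

Three compounds of this series have numbers in an assay on A10 cells for binding affinity to Endothelin-1 receptor (Rattus norvegicus); a higher number here means a weaker inhibitor, a lower number a stronger inhibitor. Compound 1 `Cc1ccccc1/C(=C\c1cc(OCc2ccsc2)ccc1C#N)C(=O)O` gives 300 nM. Compound 2 `Cc1ccccc1/C(=C\c1cc(OCc2ccsc2)ccc1Br)CO` gives 600 nM. Compound 3 `N#Cc1ccc(OCc2ccsc2)cc1/C=C(/CO)c1ccccc1` gives 800 nM, the highest of the three; its gap to compound 2 lies within the scatter, its gap to compound 1 beyond it. Compound 4 `Cc1ccccc1/C(=C\c1cc(OCc2ccsc2)ccc1C#N)CO` differs from compound 3 by methyl in place of hydrogen on an aromatic carbon. Going by the values given here, no measured pair in this set shows this change alone, so the expectation rests on the neighbouring numbers only. For compound 4 the step from compound 3 is expected to be a 1.6-fold lower number from compound 3 to compound 4 (0.20 log units; within the scatter), a modest move to a lower number that may still sit within the scatter. Compound 4 is estimated at 500 nM, with a range from 200 nM to 1200 nM.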

Compound 4, half-maximal inhibitory concentration: 300 nM
Compound 4: middle estimate off by 1.7-fold (0.22 log units), on the high side, within the range that was stated.
By their numbers in this assay, from the lowest: compounds 1, 4, 2 and 3 (each within the scatter of the next, the first and the last beyond it).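

In this assay, going by these compounds alone, phenyl to 2-methylphenyl gives a 2.7-fold lower number from compound 3 to compound 4 (0.43 log units; beyond the scatter) and is the first single-place change at this ortho position, with a step beyond the scatter. Cyano in place of bromo gives a 2.0-fold lower number from compound 2 to compound 4 (0.30 log units; within the scatter) and hydroxymethyl in place of carboxy gives no change at the digits printed from compound 1 to compound 4 (within the scatter) and both steps stay within the scatter. Nothing available accounts for the methyl step.

On these data alone, whether an ethyl, methoxy or chloro group on this aromatic carbon would give a similar step stays open. So does whether the methyl step holds in the carboxylic acid or bromo compounds.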